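The source may hold more compounds than are shown below. What is called first, only, known or untested is meant among the compounds shown, and "the series" means these compounds.

Compound 1, `CNS(=O)(=O)c1ccc2c(c1)C(n1ccccc1=O)=CC(C)(C)O2`, gives 83% in a functional assay on the whole organism (trachea) with Rattus norvegicus as the target; a lower number here means a smaller maximal response, a higher number a larger maximal response. Compound 2, `CC1(C)C=C(n2ccccc2=O)c2cc(S(=O)(=O)Nc3ccc(C#N)cc3)ccc2O1`, gives 90.8% in this assay.

Going by the values given here, compound 2 stands at the upper end of these two numbers, yet the only measured step, a number 7.8 percentage points higher from compound 1 to compound 2 (within the scatter), lies within the scatter, so the two compounds cannot really be told apart by this read-out. Compound 3, `CC1(C)C=C(n2ccccc2=O)c2cc(S(=O)(=O)Nc3ccc([N+](=O)[O-])cc3)ccc2O1`, is not yet measured. It differs from compound 2 in one place: nitro in place of cyano on an aromatic carbon. Among the compounds with values here, the one measured step concerns a different part of the molecule, the group on the sulfonamide nitrogen, and it was small. Nothing measured here speaks to swapping cyano for nitro on the aromatic ring, so the step of a number 1.8 percentage points lower from compound 2 to compound 3 (within the scatter) is expected to stay within the scatter. Compound 3 is therefore estimated at 89%, with a range from 76% to 100% in this assay.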

Compound 3, largest response reached (Emax), in percent of the reference or control that the assay uses: 75.6%
The estimate for compound 3 lay 13.4 percentage points above the measured number; the whole stated range lies above it.
By their numbers in this assay, from the lowest: compounds 3, 1 and 2 (each within the scatter of the next, the first and the last beyond it).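

Swapping cyano for nitro on the aromatic carbon para to a large group gives a number 15.2 percentage points lower from compound 2 to compound 3 (beyond the scatter) in this assay, so a change at this single ring position can be told apart from the scatter. By contrast, the step from methyl on the sulfonamide nitrogen to 4-nitrophenyl gives a number 7.4 percentage points lower from compound 1 to compound 3 (within the scatter) and so cannot be read as a real change, which leaves compound 1 inseparable from both compound 2 and compound 3. The data offer no measured explanation for the cyano-to-nitro difference.

From the compounds shown here alone, with only these two groups at this position, it remains open whether the response follows any trend across substituents. An amine, a carboxylic acid or a methoxy group on the same aromatic carbon could show whether nitro or cyano is the exception.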